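Moving the methyl: from 2-methylphenyl to 3-methylphenyl

This account rests on a few compounds, and the source may have more. Where it says the series, first, only, none or still open, it means among the compounds named here.

Working notes on a series of three measured compounds sharing one core, tested in a functional assay on MCF7 cells (Homo sapiens) for cytotoxicity, read by ELISA, with a stated time of 4 days; on this read-out lower numbers stand for stronger inhibition and higher numbers for weaker inhibition. Compound 1 `Clc1ccc(-c2cc(-c3ccoc3)cc(-c3ccco3)n2)s1` gives 4740 nM, compound 2 `Cc1ccc(-c2cc(-c3ccoc3)cc(-c3ccc(Cl)s3)n2)o1` gives 1900 nM and compound 3 `Cc1ccccc1-c1cc(-c2ccoc2)cc(-c2ccc(Cl)s2)n1` gives 1430 nM. Compound 3 cannot be separated from compound 2, as the two values lie within the scatter of each other. Going by the values given here, only two steps clear the scatter, a 3.3-fold lower number from compound 1 to compound 3 (0.52 log units; beyond the scatter) and a 2.5-fold lower number from compound 1 to compound 2 (0.40 log units; beyond the scatter), and both are modest.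

Next in line is compound 4 `Cc1cccc(-c2cc(-c3ccoc3)cc(-c3ccc(Cl)s3)n2)c1`. The change is 3-methylphenyl in place of 2-methylphenyl on an aromatic carbon, next to the ring nitrogen. Among the compounds with values here, no measured step moves a methyl around a phenyl ring, so the data give no direct reading. The nearest evidence is the exchange at this same carbon of 5-methylfuran-2-yl for 2-methylphenyl, a 1.3-fold lower number from compound 2 to compound 3 (0.12 log units; within the scatter), which stays within the scatter. The larger exchange of furan-2-yl for 2-methylphenyl, a 3.3-fold lower number from compound 1 to compound 3 (0.52 log units; beyond the scatter), is still only modest. No step beyond the scatter is therefore expected in this assay, in either direction. The expected size is a 1.0-fold higher number from compound 3 to compound 4 (0.02 log units; within the scatter). For compound 4 the estimated value is 1500 nM, with an expected range of 700 nM to 3200 nM.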

Compound 4, half-maximal inhibitory concentration: 3990 nM
The estimate for compound 4 lay 2.7-fold (0.42 log units) below the measured number, and the stated range ends below it.
By their numbers in this assay, from the lowest: compounds 3 and 2 (each within the scatter of the next); then compounds 4 and 1 (each within the scatter of the next).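

In this assay, the position of the methyl on the phenyl ring matters at this carbon next to the ring nitrogen: with the same atoms joined differently, 3-methylphenyl in place of 2-methylphenyl gives a modest step beyond the scatter (a 2.8-fold higher number from compound 3 to compound 4 (0.45 log units; beyond the scatter)), the first shift of a methyl around a phenyl ring in the series. The 3-methylphenyl group also separates from 5-methylfuran-2-yl at this carbon (a 2.1-fold higher number from compound 2 to compound 4 (0.32 log units; beyond the scatter)), whereas 2-methylphenyl did not, and against furan-2-yl it gives a step within the scatter (a 1.2-fold lower number from compound 1 to compound 4 (0.07 log units; within the scatter)), so the step beyond the scatter seen earlier with 2-methylphenyl (a 3.3-fold lower number from compound 1 to compound 3 (0.52 log units; beyond the scatter)) does not carry over to every methylphenyl group at this carbon. Nothing available on these compounds accounts for the difference between the two methylphenyl groups.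

The compounds shown leave open how 4-methylphenyl or unsubstituted phenyl would read at this carbon, and so whether 2-methylphenyl or 3-methylphenyl is the exception. They also leave open whether a methoxy group, an amine or a carboxylic acid on the phenyl ring would follow the same dependence on position.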